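The compounds below may be only part of what the source reports. "The series", "measured", "known", "first", "only" and "open" are said of these compounds alone.

Measured to date:
- compound 1 `Cc1cc(N2CC[C@@H](C)[C@@H](N(C)c3ncnc4[nH]ccc34)C2)n2nc(SCc3nc4ccccc4[nH]3)nc2n1`: 21200 nM
- compound 2 `Cc1nc2nc(SCc3ccc(Cl)cc3)nn2c(N2CC[C@@H](C)[C@@H](N(C)c3ncnc4[nH]ccc34)C2)c1C`: 90500 nM
- compound 3 `CCc1cc(N2CC[C@@H](C)[C@@H](N(C)c3ncnc4[nH]ccc34)C2)n2ncnc2n1`: 80200 nM

In a functional assay on MGC-803 cells (Homo sapiens) for inhibition, read by MTT assay, with a stated time of 72 h (a higher number here means a weaker inhibitor, a lower number a stronger inhibitor), compound 1 gives 21200 nM, the lowest of the three numbers. The nearest is compound 3, whose 80200 nM lies beyond the scatter above it; the furthest is compound 2 with 90500 nM, likewise beyond the scatter. Compound 2 and compound 3 themselves sit within the scatter of each other, so no order is drawn between them.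

The next compound in the series is compound 4 `COc1ccc(CSc2nc3nc(C)cc(N4CC[C@@H](C)[C@@H](N(C)c5ncnc6[nH]ccc56)C4)n3n2)cc1`. Relative to compound 1 it carries 4-methoxyphenyl in place of 1H-benzimidazol-2-yl on a saturated chain carbon bound to a sulfur.

Within the data shown here, no pair of measured compounds differing in one place is available, so the size of this step has no direct precedent. Compound 1 is the only one with a thioether bearing a group with a hydrogen-bond donor, and the two compounds without such a donor at that position give the higher numbers; on that basis a move toward weaker inhibition is expected, with a step of a 2.4-fold higher number from compound 1 to compound 4 (0.37 log units; beyond the scatter) in this assay. Compound 4 is therefore estimated at 50000 nM, within 15000 nM to 150000 nM.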

Compound 4, half-maximal inhibitory concentration: 15200 nM
Beside the measured number, compound 4's estimate is 3.3-fold (0.52 log units) above it; the range from low to high includes it.
By their numbers in this assay, from the lowest: compounds 4 and 1 (each within the scatter of the next); then compounds 3 and 2 (each within the scatter of the next).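

In this assay, putting 4-methoxyphenyl in place of 1H-benzimidazol-2-yl on a saturated chain carbon bound to a sulfur gives a 1.4-fold lower number from compound 1 to compound 4 (0.14 log units; within the scatter), so this pair shows no readable change at this position. The group that leaves has a hydrogen-bond donor and the group that enters has none, so in this pair the loss of that donor comes with no readable shift in the number, and the two aromatic groups cannot be ranked. No measurement at hand accounts for this result. Going by these compounds, whether the same holds for a sulfanyl group carrying a carboxylic acid, an amine or a longer alkyl chain remains open. How much the methoxy group itself contributes also remains open, as the compounds shown include no pair that isolates it.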